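Swapping a methyl for a cyano on a pyridine amide

The source may hold more compounds than are shown below. What is called first, only, known or untested is meant among the compounds shown, and "the series" means these compounds.

Measured so far:
- compound 1, `Cc1ccnc(NC(=O)c2ccccc2C)c1`, 129 uL/min
- compound 2, `Cc1cc(Br)ccc1C(=O)Nc1ccccn1`, 97 uL/min
- compound 3, `Cc1c(F)cccc1C(=O)Nc1ccccn1`, 58 uL/min

Three amides sharing a core have been run in an ADME assay (liver) for metabolic stability, with Liver microsome (Homo sapiens) as the target, read by LC-MS, using microsomes, with a stated time of 60 min, tested at 1 uM; a lower number here means slower removal, a higher number faster removal of the compound. Compound 1 gives the highest of the three numbers, 129 uL/min. Its nearest neighbour is compound 2, whose 97 uL/min lies within the usual scatter of compound 1, so the two cannot be told apart. Compound 3, at 58 uL/min, sits beyond the scatter below compound 1 and is the only one that clearly differs.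

The next compound, compound 4, `Cc1ccccc1C(=O)Nc1cc(C#N)ccn1`, is not yet measured. Compared with compound 1 the change is cyano in place of methyl on an aromatic carbon. Within the data shown here, no measured pair shows exactly this change, so the expectation rests on compound 1 alone. A modest downward step is expected, a 1.7-fold lower number from compound 1 to compound 4 (0.24 log units; within the scatter), close to the edge of the scatter rather than far beyond it. Compound 4 is therefore estimated at 75 uL/min in this assay, with a range from 35 uL/min to 150 uL/min.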

Compound 4, intrinsic clearance in a liver preparation (reported as CLH), per the amount of preparation that the assay uses: 82 uL/min
Compound 4: middle estimate off by 1.1-fold (0.04 log units), on the low side; the range from low to high includes it.
By their numbers in this assay, from the lowest: compounds 3, 4, 2 and 1 (each within the scatter of the next, the first and the last beyond it).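

In this assay, among these compounds, the cyano in place of methyl, on the aromatic carbon opposite the ring nitrogen, gives a 1.6-fold lower number from compound 1 to compound 4 (0.20 log units; within the scatter), the first comparison here in which the two compounds differ in only one place. The swap brings in a triple bond and a hydrogen-bond acceptor, yet the two compounds cannot be told apart in this measurement. Nothing available bears on why their numbers sit so close together.

It remains open whether any change at this position can move the number beyond the scatter or whether removal of these compounds barely depends on the group there. An amine or a methoxy group at the same place would test this, and so would a carboxylic acid.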